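Benzyl Variation on a Piperidinol-Linked Pyrazolopyrimidinone Core

The compounds below may be only part of what the source reports. "The series", "measured", "known", "first", "only" and "open" are said of these compounds alone.

Measured compounds:
compound 2 `O=c1c2cnn(-c3ccc(F)cc3)c2ncn1CC1(O)CCN(Cc2ccc(Cl)cc2)CC1`, 8000 nM
compound 3 `N#Cc1ccccc1CN1CCC(O)(Cn2cnc3c(cnn3-c3ccc(F)cc3)c2=O)CC1`, 8100 nM

Compound 1 `O=c1c2cnn(-c3ccc(F)cc3)c2ncn1CC1(O)CCN(Cc2cccnc2)CC1` carries a pyridin-3-ylmethyl group at the ring amine. In an assay on Sf21 cells for inhibition of ubiquitin carboxyl-terminal hydrolase 7 (Homo sapiens), read by spectrophotometry, with stated times of 30 min and 2 h (on this read-out lower numbers stand for stronger inhibition and higher numbers for weaker inhibition), compound 1 gives "not determined" (no result reported). In this assay compound 2 gives 8000 nM and compound 3 gives 8100 nM. Compound 3 holds the highest of the two numbers, with compound 2 within the scatter: a 1.0-fold higher number from compound 2 to compound 3 (0.01 log units; within the scatter). Compound 4 `COC(=O)c1ccc(CN2CCC(O)(Cn3cnc4c(cnn4-c4ccc(F)cc4)c3=O)CC2)c(F)c1` differs from compound 3 by 2-fluoro-4-(methoxycarbonyl)phenyl in place of 2-cyanophenyl on a saturated chain carbon bound to an amine nitrogen in a ring. Within the data shown here, the only step bearing on it, the swap of one benzyl substituent for another, was flat, so no change beyond the scatter is expected: a 1.0-fold lower number from compound 3 to compound 4 (0.01 log units; within the scatter). Compound 4 is estimated at 8000 nM, expected between 3000 nM and 20000 nM.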

Compound 4, half-maximal inhibitory concentration: 800 nM
Compound 4: middle estimate off by 10-fold (1.00 log units), on the high side, outside the stated range (below it).
By their numbers in this assay, from the lowest: compound 4; then compounds 2 and 3 (each within the scatter of the next).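

In this assay this position on the saturated chain carbon bound to the ring amine nitrogen turns out not to be flat: 2-fluoro-4-(methoxycarbonyl)phenyl gives a 10-fold lower number from compound 3 to compound 4 (1.01 log units; beyond the scatter) against 2-cyanophenyl and a 10-fold lower number from compound 2 to compound 4 (1.00 log units; beyond the scatter) against 4-chlorophenyl, whereas the earlier step between those two groups stayed within the scatter. Nothing measured here accounts for this shift.

The fluorine and the methoxycarbonyl group enter together, and the compounds shown do not separate them. Also open, going by these compounds, is whether a carboxylic acid or a primary amide in place of the methyl ester would keep the lower number.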